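Nitro substituent on the shared core: cytotoxicity expectation

A few compounds are considered here, and "the series" means these few. Any claim that something is new, unique, unknown or untested is made for them only; others in the source may bear on it.

Measured so far:
compound 1, `C/C(=C\c1cc(-c2ccccc2)cs1)C(N)=O`: 2680 nM
compound 2, `C/C(=C\c1cccc(-c2ccccc2)c1)C(N)=O`: 6540 nM
compound 3, `C/C(=C\c1cc(-c2ccccc2C)cs1)C(N)=O`: 4920 nM

All three numbers come from a functional assay on MCF7 cells (Homo sapiens) for cytotoxicity, read by CCK-8 assay, with a stated time of 24 h; on this read-out lower numbers stand for stronger inhibition and higher numbers for weaker inhibition. Compound 1 stands at the lowest of the three values. Its nearest neighbour is compound 3, reached by a 1.8-fold higher number from compound 1 to compound 3 (0.26 log units; within the scatter), a change that stays within the scatter of repeated measurements. Compound 2, with 6540 nM, lies further off, a gap beyond the scatter.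

The unmeasured compound 4, `C/C(=C\c1cc(-c2ccc([N+](=O)[O-])cc2)cs1)C(N)=O`, differs from compound 1 in one place: nitro in place of hydrogen on an aromatic carbon. Within the data shown here, this is the only step to judge from, and the single measured step that bears on it is the one from compound 1 to compound 3, where a methyl also replaced a hydrogen on an aromatic carbon and the number moved only within the scatter. Among the measured compounds shown here, the nitro group is a different kind of substituent from a methyl, and no measured pair here shows what such a group does, so the change remains uncertain. The expectation is therefore a number close to that of compound 1, with no step beyond the scatter in this assay.

Compound 4 is estimated at 3000 nM, between 1200 nM and 8000 nM, which means an expected step of a 1.1-fold higher number from compound 1 to compound 4 (0.05 log units; within the scatter).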

Compound 4, half-maximal inhibitory concentration: 1210 nM
Beside the measured number, compound 4's estimate is 2.5-fold (0.39 log units) above it; low and high end bracket the measured number.
By their numbers in this assay, from the lowest: compound 4; then compounds 1, 3 and 2 (each within the scatter of the next, the first and the last beyond it).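

In this assay, the six-membered aromatic ring of carbon only accepts a substituent para to a large group, and the number goes down: nitro in place of hydrogen gives a 2.2-fold lower number from compound 1 to compound 4 (0.35 log units; beyond the scatter). Among these compounds, this is the first single change on that ring to move the number beyond the scatter, whereas methyl in place of hydrogen, with a 1.8-fold higher number from compound 1 to compound 3 (0.26 log units; within the scatter), stayed within it, so the ring is not indifferent to every group it carries, although the nitro step is modest and rests on one pair of compounds. Nothing measured here explains why the nitro compound gives the lower number.

On these data alone, it remains open whether this lower number is particular to nitro or would also appear with another group in the same place, such as an amine, a carboxylic acid or a methoxy group. It is also unknown whether nitro would give a similar step at another carbon of this ring, or on the ring that carries the phenyl group in compound 2.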